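A few compounds are considered here, and "the series" means these few. Any claim that something is new, unique, unknown or untested is made for them only; others in the source may bear on it.

In a functional assay on NCI-H460 cells (Homo sapiens) for cytotoxicity, read by MTT assay, with a stated time of 72 h (a lower number here means a stronger inhibitor, a higher number a weaker inhibitor), compound 1 `Cc1ccc(S(=O)(=O)n2cc(COC3=C/C(=N\c4ccc(Br)cc4)c4ccccc4C3=O)nn2)cc1` gives 9410 nM and compound 2 `Cc1ccc(/N=C2\C=C(OCc3cn(S(=O)(=O)c4ccc(C)cc4)nn3)C(=O)c3ccccc32)cc1` gives 8020 nM, so these two values stand within the scatter of each other. Compound 3 `Cc1ccc(S(=O)(=O)n2cc(COC3=C/C(=N\c4ccc(F)cc4)c4ccccc4C3=O)nn2)cc1` differs from compound 2 by fluoro in place of methyl on an aromatic carbon. Among the compounds with values here, the one measured step that bears on this change is a 1.2-fold lower number from compound 1 to compound 2 (0.07 log units; within the scatter), methyl in place of bromo on an aromatic carbon. Within the data shown here, with only that small step to go on, no step beyond the scatter is expected in this assay. Compound 3 is estimated at 8500 nM, with an expected range from 4500 nM to 16000 nM. The estimated step is a 1.1-fold higher number from compound 2 to compound 3 (0.03 log units; within the scatter).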

Compound 3, half-maximal inhibitory concentration: 7360 nM
Estimate against measurement, compound 3: 1.2-fold (0.06 log units) above, and the stated range covers the measured number.
By their numbers in this assay, from the lowest: compounds 3, 2 and 1 (each within the scatter of the next).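

Fluoro in place of methyl on the aromatic carbon para to a large group (a 1.1-fold lower number from compound 2 to compound 3 (0.04 log units; within the scatter)) and fluoro in place of bromo (a 1.3-fold lower number from compound 1 to compound 3 (0.11 log units; within the scatter)) both stay within the scatter in (this assay). Bromo, methyl and fluoro at this position therefore do not separate the three compounds. The earlier picture held for a single comparison, and it now holds for three groups. As far as these compounds go, whether an amine, a carboxylic acid or a methoxy group at this position would move the number beyond the scatter stays open. Nothing available explains the result.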